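The source may hold more compounds than are shown below. What is called first, only, known or untested is meant among the compounds shown, and "the series" means these compounds.

Compound 3 `Cc1ccc(C(=O)CCc2nnc(-c3ccccc3Cl)o2)cc1` stands second highest of the three numbers in a functional assay on the whole organism (strain Wistar) for inhibition, with Rattus norvegicus as the target, with stated times of 30 min and 2 h, at a dose of 20 mg/kg by the oral route; on this read-out lower numbers stand for less inhibition and higher numbers for more inhibition at the one dose given (going by the name of the read-out); its nearest neighbour is compound 2 `Cc1ccc(C(=O)CCc2nnc(-c3ccccc3)o2)cc1`, which gives 33.3% against compound 3 at 36.2%, and the furthest is compound 1 `O=C(CCc1nnc(-c2ccc(Cl)cc2)o1)c1ccccc1`, which gives 42%. The step of a number 2.9 percentage points higher from compound 2 to compound 3 (within the scatter) is within the scatter. Compound 4 `Cc1ccc(C(=O)CCc2nnc(-c3ccc(Cl)cc3)o2)cc1` differs from compound 3 by 4-chlorophenyl in place of 2-chlorophenyl on an aromatic carbon. Among the compounds with values here, no measured step moves a chloro around the phenyl ring at this place; the one step that bears on it, compound 2 to compound 3, was small, and compound 1 with the same 4-chlorophenyl gives 42%. No step beyond the scatter is therefore expected in this assay. For compound 4 the expected step is a number 1.8 percentage points higher from compound 3 to compound 4 (within the scatter), an estimate of 38% with a range from 28% to 48%.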

Compound 4, a percentage reported as inhibition, in the whole organism at one dose (the size of the read-out at that dose, not a potency): 62.7%
Compound 4: middle estimate off by 24.7 percentage points, on the low side, outside the stated range (above it).
By their numbers in this assay, from the lowest: compounds 2, 3 and 1 (each within the scatter of the next); then compound 4.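

In this assay the place of the chloro on the phenyl ring matters: 4-chlorophenyl in place of 2-chlorophenyl gives a number 26.5 percentage points higher from compound 3 to compound 4 (beyond the scatter), which 2-chlorophenyl alone did not foreshadow. Chloro in place of hydrogen gives a number 29.4 percentage points higher from compound 2 to compound 4 (beyond the scatter) when it enters as 4-chlorophenyl, in contrast to the step within the scatter for 2-chlorophenyl. With 4-chlorophenyl held fixed, the methyl also counts, giving a number 20.7 percentage points higher from compound 1 to compound 4 (beyond the scatter) as a further rise. Open, from the compounds shown here alone, is whether fluoro, methoxy or an amine in place of the chloro of 4-chlorophenyl would hold the level of compound 4. No measurement at hand accounts for these steps.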